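From methyl to methoxy on the aromatic ring

A few compounds are considered here, and "the series" means these few. Any claim that something is new, unique, unknown or untested is made for them only; others in the source may bear on it.

In an ADME assay on microsomes from liver (Homo sapiens) for metabolic stability (on this read-out higher numbers stand for fast clearance and lower numbers for slow clearance), compound 1 (`COc1ccc([C@H](C)NC(=O)Cn2nnc3ccccc3c2=O)cc1`) gives 13 mL/min/kg and compound 2 (`Cc1ccc([C@H](C)NC(=O)C(C)n2nnc3ccccc3c2=O)cc1`) gives 13 mL/min/kg as well, so compound 2 stands level with compound 1 within the scatter. Compound 3 (`COc1ccc([C@H](C)NC(=O)C(C)n2nnc3ccccc3c2=O)cc1`) carries methoxy in place of methyl on an aromatic carbon of compound 2 (methoxy in place of methyl on an aromatic carbon). Among the compounds with values here, no measured pair isolates this change, so no step beyond the scatter is expected in this assay, in either direction. The estimated move, a 1.1-fold higher number from compound 2 to compound 3 (0.03 log units; within the scatter), is small. Compound 3 is expected at 14 mL/min/kg, within an estimated range of 7 mL/min/kg to 26 mL/min/kg.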

Compound 3, clearance: < 9.9 mL/min/kg
Compound 3: no number, only a limit; the forecaster's own chance of this, stated with the estimate: 5%; at least 1.4-fold (0.15 log units) between middle value and limit.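

Compound 3 gives no number in this assay, only a limit: the limit of < 9.9 mL/min/kg in this assay, at which 1 of the 3 values shown sits. Methoxy in place of methyl on the aromatic carbon gives an at least 1.3-fold lower number from compound 2 to compound 3 (0.11 log units; that floor lies within the scatter), and methyl in place of hydrogen on the saturated chain carbon gives an at least 1.3-fold lower number from compound 1 to compound 3 (0.11 log units; that floor lies within the scatter). Both changes point the same way, but neither floor establishes a step beyond the scatter.

Going by these compounds, how far compound 3 lies past its limit stays open. So does how an ethoxy group or a chlorine atom on that aromatic carbon, or an ethyl group on the chain carbon, would read in this assay.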